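Exchanging One Arm on the Shared Core

The source may hold more compounds than are shown below. What is called first, only, known or untested is meant among the compounds shown, and "the series" means these compounds.

compound 1, `CCOC(=O)[C@@H]1CCCN(S(=O)(=O)c2ccc(S(=N)(=O)N(CC)CC)cc2)C1`: 2600 nM
compound 2, `CCOC(=O)[C@@H]1CCCN(S(=O)(=O)c2ccc(S(=O)(=O)N(CC)CC)cc2C)C1`: 5100 nM

Within the data shown here, in a functional assay on MIA PaCa-2 cells (Homo sapiens) for inhibition, read by MTT assay, with a stated time of 7 days (a lower number here means a stronger inhibitor, a higher number a weaker inhibitor), compound 1 gives 2600 nM, the lower of the two numbers measured so far. Compound 2 gives 5100 nM, a gap that lies within the scatter, so the two cannot be ranked. Compound 3 `CCCN(CCC)S(=O)(=O)c1ccc(S(=O)(=O)N2CCC[C@@H](C(=O)OCC)C2)cc1` has not been measured. Against compound 1 it shows (a group of 10 heavy atoms (6 carbon, 1 nitrogen, 2 oxygen, 1 sulfur; no ring) in place of a group of 8 heavy atoms (4 carbon, 2 nitrogen, 1 oxygen, 1 sulfur; no ring), on an aromatic carbon). Among the measured compounds shown here, no step between measured compounds covers this change, so in this assay only a small shift is expected, possibly none beyond the scatter. Compound 3 is therefore estimated at 3500 nM, with a range from 1200 nM to 10000 nM. That estimate would mean an expected step of a 1.3-fold higher number from compound 1 to compound 3 (0.13 log units; within the scatter).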

Compound 3, half-maximal inhibitory concentration: 2300 nM
Compound 3: the middle estimate sits 1.5-fold (0.18 log units) above what was measured; measured number inside the range.
By their numbers in this assay, from the lowest: compounds 3, 1 and 2 (each within the scatter of the next, the first and the last beyond it).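

Putting dipropylsulfamoyl on this aromatic carbon, para to a large group, gives a 1.1-fold lower number from compound 1 to compound 3 (0.05 log units; within the scatter) in this assay. Going by these compounds, at this position, therefore, a group of 10 heavy atoms with 0 hydrogen-bond donors can replace a group of 8 heavy atoms with 1 hydrogen-bond donor without a shift that can be told from the scatter. (No supporting measurement bears on this result) It remains open whether a primary amine or a carboxylic acid at this position would move the number beyond the scatter. A longer chain than propyl on the sulfamoyl nitrogen is equally untested here.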